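Phenyl on the ether chain of the shared core

The source may report more compounds than this note shows. Statements on the series, on what has been measured and on what is new or still open speak of the compounds shown alone.

Compound 2 `CCCOc1ccc2c(c1)SCC(=O)N2` holds the lower of the two numbers obtained so far: in an assay on isolated protein for inhibition of Amine oxidase [flavin-containing] A (Homo sapiens), read by fluorescence and spectrophotometry, with a stated time of 20 min (a higher number here means a weaker inhibitor, a lower number a stronger inhibitor), compound 2 gives 6510 nM, whereas compound 1 `O=C1CSc2cc(OCCCc3ccccc3)ccc2N1` gives 96800 nM. Compound 3 `O=C1CSc2cc(OCCc3ccccc3)ccc2N1` differs from compound 2 by phenyl in place of methyl on a saturated chain carbon, two bonds along the chain from an oxygen on an aromatic ring. Within the data shown here, the only step that bears on this change is the removal of a phenyl from the same chain, a 15-fold lower number from compound 1 to compound 2 (1.17 log units; beyond the scatter). Putting a phenyl back onto that chain is therefore expected to move the number in the opposite direction, by a step of comparable size, a 6.1-fold higher number from compound 2 to compound 3 (0.79 log units; beyond the scatter). Compound 3 is accordingly estimated at 40000 nM, within a range of 10000 nM to 150000 nM.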

Compound 3, half-maximal inhibitory concentration: 13100 nM
For compound 3 the middle estimate is 3.1-fold (0.48 log units) above the measured one, and the stated range covers the measured number.
By their numbers in this assay, from the lowest: compounds 2 and 3 (each within the scatter of the next); then compound 1.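

Phenyl in place of methyl at this carbon, two bonds along the chain from an oxygen on an aromatic ring, stays within the scatter: a 2.0-fold higher number from compound 2 to compound 3 (0.30 log units; within the scatter). Phenyl in place of benzyl at the same carbon gives a 7.4-fold lower number from compound 1 to compound 3 (0.87 log units; beyond the scatter), so among these compounds a terminal phenyl alone does not set the high number, since compound 3 also carries one and only compound 1 stands apart. Nothing available accounts for either step.

Open, going by these compounds, is how an amine or a carboxylic acid at the chain end would read. Also open, on these data alone, is whether a substituent on the terminal phenyl, such as fluoro or methoxy, would shift the number.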